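The source may hold more compounds than are shown below. What is called first, only, known or untested is meant among the compounds shown, and "the series" means these compounds.

Measured so far:
compound 1 `CC1=CCC2C(CC[C@@]2(C)O)C(C)(C)C1CC[C@@H]1[C@@]2(C)CCC(=O)C(C)(C)O[C@@H]2CC[C@]1(C)O` — > 50000 nM
compound 2 `CC1=CC[C@H]2[C@H](CC[C@]2(C)O)C(C)(C)[C@@H]1CC[C@H]1[C@]2(C)CC[C@H](OC(=O)c3ccccc3)C(C)(C)O[C@H]2CC[C@@]1(C)O` — 16100 nM
compound 3 `CC1=CC[C@H]2[C@@H]1CC=C(C)[C@@H](CC[C@H]1[C@]3(C)CC[C@H](OC(=O)c4ccc(Cl)cc4)C(C)(C)O[C@H]3CC[C@@]1(C)O)C2(C)C` — 12700 nM

In a functional assay on MDA-MB-231 cells (Homo sapiens) for antiproliferative activity, read by MTT assay, with a stated time of 72 h (on this read-out lower numbers stand for stronger inhibition and higher numbers for weaker inhibition), compound 2, at 16100 nM, gives the highest of the two numbers reported. Compound 3 gives 12700 nM, which lies within the scatter of compound 2, so no order between the two is claimed. The value of compound 1 is a limit of the assay, not a number (the limit of > 50000 nM in this assay, at which 1 of the 3 values shown sits).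

Compound 4 `CC1=CC[C@H]2[C@H](CC[C@]2(C)O)C(C)(C)[C@@H]1CC[C@H]1[C@]2(C)CC[C@H](OC(=O)c3cccc(C(F)(F)F)c3)C(C)(C)O[C@H]2CC[C@@]1(C)O` differs from compound 2 by trifluoromethyl in place of hydrogen on an aromatic carbon. Going by the values given here, no measured pair isolates a change of this kind, and compound 3 differs from compound 2 in its core as well, so it offers no guide. The step in this assay is expected to be none beyond the scatter. Compound 4 is expected at 14000 nM, ranging from 5000 nM to 40000 nM. This amounts to an expected step of a 1.2-fold lower number from compound 2 to compound 4 (0.06 log units; within the scatter).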

Compound 4, half-maximal inhibitory concentration: 36300 nM
Compound 4: middle estimate off by 2.6-fold (0.41 log units), on the low side; the measured number falls inside the stated range.
By their numbers in this assay, from the lowest: compounds 3 and 2 (each within the scatter of the next); then compound 4. At a limit, above all of these: compound 1.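

In this assay, going by these compounds alone, trifluoromethyl in place of hydrogen on an aromatic carbon, meta to a large group, raises the number (a 2.3-fold higher number from compound 2 to compound 4 (0.35 log units; beyond the scatter)) and so gives the first single-place step. This carbon of the benzoyl ring therefore responds to substitution, modestly and in the direction of weaker inhibition. Compound 1 remains a limit, not a number, and the readable range ends there: the limit of > 50000 nM in this assay, at which 1 of the 4 values shown sits.

Still open, as far as these compounds go, is whether a methoxy group or an amine on this carbon would shift the number the same way. Also open, from the compounds shown here alone, is whether trifluoromethyl elsewhere on the ring would do so.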